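A few compounds are considered here, and "the series" means these few. Any claim that something is new, unique, unknown or untested is made for them only; others in the source may bear on it.

Three nucleoside analogues were examined in a functional assay on P815 cells (Mus musculus) for antiproliferative activity; on this read-out higher numbers stand for weaker inhibition and lower numbers for stronger inhibition. Compound 1 `Nc1ccn(C2OC(CO)C(Br)C2O)c(=O)n1` gives 0.05 ug/mL, and compound 3 `Nc1nc(=O)n(C2OC(CO)C(Br)C2O)cc1F` gives 0.2 ug/mL. These two differ in one place, (hydrogen in place of fluoro on an aromatic carbon), and that change produces a 4.0-fold lower number from compound 3 to compound 1 (0.60 log units; beyond the scatter). Compound 2 `CS(=O)(=O)O[C@@H]1[C@@H](O)[C@H](n2cc(F)c(N)nc2=O)O[C@@H]1CO` gives 0.02 ug/mL, the lowest number of the three; how its core differs from that of compound 3 is not broken down here. Compound 4 `CS(=O)(=O)O[C@@H]1[C@@H](O)[C@H](n2ccc(N)nc2=O)O[C@@H]1CO` remains to be measured. It differs from compound 2 by hydrogen in place of fluoro on an aromatic carbon. This is the same kind of change as that from compound 3 to compound 1, though the surroundings differ: in compound 4 the site is meta to a large group, whereas in compound 1 it is meta to a group of 9 heavy atoms. Resting on the step from compound 3 to compound 1, compound 4 is expected to show a 4.0-fold lower number from compound 2 to compound 4 (0.60 log units; beyond the scatter) in this assay. Compound 4 is therefore estimated at 0.005 ug/mL, plausibly between 0.002 ug/mL and 0.015 ug/mL.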

Compound 4, concentration for 50% inhibition: 0.03 ug/mL
The estimate for compound 4 lay 6.0-fold (0.78 log units) below the measured number, outside the stated range (above it).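

In this assay the exchange of fluoro for hydrogen did not carry over from one core to the other: the same change on two cores in this assay, a 4.0-fold lower number (0.60 log units; beyond the scatter) from compound 3 to compound 1 and a 1.5-fold higher number (0.18 log units; within the scatter) from compound 2 to compound 4, 6.0-fold (0.78 log units) apart, beyond the scatter of two such steps

On the core of compound 2 the change gives a 1.5-fold higher number from compound 2 to compound 4 (0.18 log units; within the scatter), so compound 2 and compound 4 cannot be told apart, whereas on the core of compound 3 it gives a 4.0-fold lower number from compound 3 to compound 1 (0.60 log units; beyond the scatter). This shows that a step read on one core cannot simply be transferred to another in this series, but two pairs do not show why the cores differ or how a further core would respond.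

From the compounds shown here alone, it remains open how chloro or methyl would compare with fluoro and hydrogen on the same aromatic carbon. Also open, going by these compounds, is how an azide or an amine would fare in place of the bromo group of compound 1 or the methanesulfonate of compound 4.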